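The source may hold more compounds than are shown below. What is called first, only, known or untested is meant among the compounds shown, and "the series" means these compounds.

Compound 1 `O=C(N/N=C/c1c(-c2cc3ccccc3oc2=O)[nH]c2ccccc12)c1ccc(Cl)cc1` and compound 2 `O=C(N/N=C/c1c(-c2cc3ccccc3oc2=O)[nH]c2ccccc12)c1ccccc1F` share their core with compound 3 `O=C(N/N=C/c1c(-c2cc3ccc(Br)cc3oc2=O)[nH]c2ccccc12)c1ccc(Cl)cc1`. In a toxicity assay on Vero cells (Chlorocebus sabaeus) for inhibition, read by MTT assay, with a stated time of 48 h (on this read-out lower numbers stand for stronger inhibition and higher numbers for weaker inhibition), compound 1 gives only a limit, > 200000 nM. Compound 2 likewise gives only a limit, > 200000 nM, in this assay. Among the compounds with values here, compound 3 is the sole compound with a number, 71400 nM, in this assay. The step of an at least 2.8-fold lower number from compound 1 to compound 3 (0.44 log units; beyond the scatter) went with bromo in place of hydrogen on an aromatic carbon. The step that the two limits leave unreadable from compound 1 to compound 2 cannot be sized because of the limit of > 200000 nM in this assay, at which 2 of the 3 values shown sit. Compound 4 `O=C(N/N=C/c1c(-c2cc3ccc(Br)cc3oc2=O)[nH]c2ccccc12)c1cccc(Br)c1` differs from compound 3 by 3-bromophenyl in place of 4-chlorophenyl on a carbonyl carbon. Within the data shown here, the only step that bears on this change of the ring on the carbonyl carbon is unreadable, so the chemist expects no step beyond the scatter, a 1.0-fold lower number from compound 3 to compound 4 (0.01 log units; within the scatter). Compound 4 is thus expected to give 70000 nM, between 25000 nM and 200000 nM.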

Compound 4, half-maximal inhibitory concentration: > 200000 nM
Compound 4 ended at the assay's limit; the forecaster's own chance of this, stated with the estimate: 30%; at least 2.8-fold (0.45 log units) between middle value and limit.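

In this assay, a change of the ring on the carbonyl carbon now gives a readable step, an at least 2.8-fold higher number from compound 3 to compound 4 (0.44 log units; beyond the scatter), so this position is not indifferent on the bromo-bearing core. Within the data shown here, compound 3 remains the only compound with a number, and compound 4 gives only a limit. The other steps that end at that limit cannot be read: the limit of > 200000 nM in this assay, at which 3 of the 4 values shown sit.

The step from 4-chlorophenyl to 3-bromophenyl changes both the halogen and its ring position, and the compounds shown do not separate the two. On these data alone, how an amine or a carboxylic acid on this ring would read also stays open.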